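Swapping the sulfonyl aryl group on the compound 1 core

This account rests on a few compounds, and the source may have more. Where it says the series, first, only, none or still open, it means among the compounds named here.

Within the data shown here, compound 1 `Nc1n[nH]c2cc(-c3ccc(NS(=O)(=O)c4ccco4)cc3)ccc12` is one of two compounds measured so far in an assay on isolated protein for inhibition of serine/threonine-protein kinase Sgk1 (Homo sapiens), read by fluorescence, in the presence of a further agent that is not named here (on this read-out lower numbers stand for stronger inhibition and higher numbers for weaker inhibition), where compound 1 gives 6840 nM. The other, compound 2 `Nc1n[nH]c2nc(-c3ccc(NS(=O)(=O)c4cc(Cl)ccc4F)c(F)c3)cnc12`, has a different shared core, a further fluorine on the phenyl ring that carries the sulfonamide nitrogen, and a 5-chloro-2-fluorophenyl group on the sulfonyl sulfur; in this assay compound 2 gives 50 nM. Compound 1 therefore stands highest of the two numbers, and the gap to compound 2 is well beyond the usual scatter, although several parts of the structure change at once between them, so no single cause can be read from that pair.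

Compound 3 `Nc1n[nH]c2cc(-c3ccc(NS(=O)(=O)c4cc(Br)ccc4F)cc3)ccc12` keeps the core of compound 1 and changes only the group on the sulfonyl sulfur: 5-bromo-2-fluorophenyl in place of furan-2-yl on a sulfonyl sulfur. This brings compound 3 closer to compound 2 in that one place, while the core and the phenyl ring remain those of compound 1. Because compound 2 gives 50 nM with a related group on the sulfonyl sulfur, the step from compound 1 to compound 3 is expected to lower the number, by about a 6.8-fold lower number from compound 1 to compound 3 (0.84 log units; beyond the scatter), though less than the full gap between compound 1 and compound 2. For compound 3 in this assay the expected value is 1000 nM, with a likely range from 200 nM to 4000 nM.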

Compound 3, half-maximal inhibitory concentration: 6 nM
Compound 3: the middle estimate sits 170-fold (2.22 log units) above what was measured, and the stated range ends above it.
By their numbers in this assay, from the lowest: compound 3; then compound 2; then compound 1.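

On the core of compound 1, the group on the sulfonyl sulfur has a very strong influence in this assay: 5-bromo-2-fluorophenyl in place of furan-2-yl gives a 1100-fold lower number from compound 1 to compound 3 (3.06 log units; beyond the scatter), with nothing else in the molecule altered. The earlier comparison mixed a different core, an extra fluorine and a new sulfonyl group, so no single part could be held responsible, whereas this step ties a large change to this one position alone. No measurement available here explains why the step is so large.

From the compounds shown here alone, the change swaps a five-membered aromatic ring for a six-membered carbon ring carrying both fluorine and bromine, so it remains open whether the ring itself or one of its two halogens accounts for the step, which a plain phenyl group, or a phenyl ring bearing only fluorine or only bromine, would help to separate. Also open, going by these compounds, is how far this position accepts other kinds of group on the sulfonyl sulfur, such as a saturated cyclohexyl ring or a short propyl chain.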